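This account rests on a few compounds, and the source may have more. Where it says the series, first, only, none or still open, it means among the compounds named here.

Measured compounds:
compound 1, `CC[C@H](C)[C@H](NC(=O)c1cccc(Cn2ccnc2)c1)C(=O)NNS(=O)(=O)c1ccccc1`: 6%
compound 2, `CCCCCS(=O)(=O)NNC(=O)[C@@H](NC(=O)c1cccc(Cn2ccnc2)c1)[C@@H](C)CC`: "not determined" (no result reported)

In an assay on HEK293 cells for displacement of a labelled ligand from Type-2 angiotensin II receptor (Homo sapiens), tested at 1 uM (on this read-out higher numbers stand for a stronger effect at the one concentration tested and lower numbers for a weaker effect), compound 1 gives 6%, a weak effect at the single concentration tested. Compound 2 gives "not determined" (no result reported) in this assay, so it has no single number and cannot be placed against compound 1. Compound 3, `CC[C@H](C)[C@H](NC(=O)c1cccc(Cn2ccnc2)c1)C(=O)NO`, differs from compound 2 by hydroxy in place of (pentylsulfonyl)amino on an amide-type nitrogen. Within the data shown here, with no measured step between these compounds to rest on, the change is expected to shift the read-out by no more than the usual scatter, in no particular direction. Compound 3 is therefore expected to give about 8% in this assay, with a range from -5% to 25%.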

Compound 3, a percentage reported as inhibition, at one concentration (the size of the read-out at that concentration, not a potency): "not active" (no number reported)
Compound 3 has no reported number here, and the estimate cannot be compared.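

In this assay, among these compounds, neither compound 2 nor compound 3 has a number, so no step between them can be read. How (pentylsulfonyl)amino and hydroxy compare stays open, and nothing shown bears on an explanation.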